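Replacing the Methoxymethyl Group of Compound 2

The compounds below may be only part of what the source reports. "The series", "measured", "known", "first", "only" and "open" are said of these compounds alone.

Measured so far:
- Compound 1 `CC(C)=CCC[C@]1(C)/C=C/[C@@H](OC(=O)C=C(C)C)[C@](C)(O)/C=C/C(=O)/C(C[Si](C)(C)C(C)(C)C)=C\C1`: 3350 nM
- Compound 2 `COCOC/C1=C/C[C@](C)(CCC=C(C)C)/C=C/[C@@H](OC(=O)C=C(C)C)[C@](C)(O)/C=C/C1=O`: 3710 nM

In a functional assay on SW480 cells (Homo sapiens) for antiproliferative activity, read by MTT assay, with a stated time of 48 h (on this read-out higher numbers stand for weaker inhibition and lower numbers for stronger inhibition), compound 2 at 3710 nM cannot be told apart from compound 1 at 3350 nM. Compound 3 `CSC(=S)OC/C1=C/C[C@](C)(CCC=C(C)C)/C=C/[C@@H](OC(=O)C=C(C)C)[C@](C)(O)/C=C/C1=O` is not yet measured, and it differs from compound 2 as follows: a group of 4 heavy atoms (2 carbon, 2 sulfur; no ring) in place of a group of 3 heavy atoms (2 carbon, 1 oxygen; no ring), on an oxygen on a saturated carbon. Among the compounds with values here, only one measured step offers guidance: a 1.1-fold higher number from compound 1 to compound 2 (0.04 log units; within the scatter). That step also exchanged one group for a quite different one, yet stayed within the scatter. One small step is thin evidence, so the range is kept wide. The expected change is therefore no larger than the scatter, a 1.2-fold lower number from compound 2 to compound 3 (0.09 log units; within the scatter). For compound 3 the estimate is 3000 nM, with an expected range of 1200 nM to 7000 nM.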

Compound 3, half-maximal inhibitory concentration: 390 nM
Compound 3: middle estimate off by 7.7-fold (0.89 log units), on the high side; measured number below the stated range.
By their numbers in this assay, from the lowest: compound 3; then compounds 1 and 2 (each within the scatter of the next).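

In this assay, this position proves sensitive to what it carries: putting the sulfur-containing group in place of methoxymethyl on the oxygen gives a 9.5-fold lower number from compound 2 to compound 3 (0.98 log units; beyond the scatter), a clear move beyond the scatter. Within the data shown here, the comparison with the silicon-containing group points the same way, with an 8.6-fold lower number from compound 1 to compound 3 (0.93 log units; beyond the scatter), whereas the only earlier step stayed within the scatter. Nothing measured here explains the drop.

Going by these compounds, it remains open whether the sulfur atoms themselves matter, or only the shape of the group. A methyl carbonate, with oxygen in place of both sulfurs, or an amine on the same saturated carbon would help separate these possibilities.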